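Changing the Aromatic Group on the Amide Carbonyl

The source may hold more compounds than are shown below. What is called first, only, known or untested is meant among the compounds shown, and "the series" means these compounds.

In a functional assay on MDA-MB-231 cells (Homo sapiens) for antiproliferative activity, read by MTT assay, with a stated time of 24 h (a higher number here means a weaker inhibitor, a lower number a stronger inhibitor), compound 1 (`COC(=O)c1scc(-c2ccc(NC(=O)c3ccc4ccccc4c3)cc2)c1OC`) gives 5250 nM and compound 2 (`COC(=O)c1scc(-c2ccc(NC(=O)c3ccccn3)cc2)c1OC`) gives 8250 nM, so these two values lie within the usual scatter of each other. Compound 3 (`COC(=O)c1scc(-c2ccc(NC(=O)c3cccc(C(F)(F)F)c3)cc2)c1OC`) carries 3-(trifluoromethyl)phenyl in place of pyridin-2-yl on a carbonyl carbon. Among the compounds with values here, the only measured step, a 1.6-fold higher number from compound 1 to compound 2 (0.20 log units; within the scatter), also exchanged the group on that carbonyl carbon, so no change beyond the scatter is expected in this assay. The expected step is a 1.3-fold lower number from compound 2 to compound 3 (0.10 log units; within the scatter). For compound 3 the estimated value is 6500 nM, with an expected range of 2800 nM to 15000 nM.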

Compound 3, half-maximal inhibitory concentration: 24600 nM
Estimate against measurement, compound 3: 3.8-fold (0.58 log units) below, outside the stated range (above it).
By their numbers in this assay, from the lowest: compounds 1 and 2 (each within the scatter of the next); then compound 3.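

Within the data shown here, the group on this carbonyl carbon can change the result in this assay by more than the scatter, which the first pair of compounds did not show. The step of a 3.0-fold higher number from compound 2 to compound 3 (0.47 log units; beyond the scatter) and the step of a 4.7-fold higher number from compound 1 to compound 3 (0.67 log units; beyond the scatter) both leave 3-(trifluoromethyl)phenyl as the weakest of the three. Nothing measured here explains this difference.

On these data alone, it remains open whether the trifluoromethyl group or the carbon-only ring accounts for the change. A plain phenyl, or a ring carrying a methyl, an amine or a carboxylic acid in place of trifluoromethyl, would help separate the two.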